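Methyl in Place of Hydrogen: What Is Expected of Compound 4

The source may report more compounds than this note shows. Statements on the series, on what has been measured and on what is new or still open speak of the compounds shown alone.

Three compounds were measured in an in vitro functional assay on 1321-N1 cells for agonist activity at Free fatty acid receptor 1 (Homo sapiens), read by fluorescence, spectrophotometry and calcium flux; a higher number here means a larger maximal response, a lower number a smaller maximal response. Compound 1 `Cc1c(C#Cc2ccc(CCC(=O)O)cc2)ccnc1Cl` gives 101%, compound 2 `O=C(O)CCc1ccc(C#Cc2ccnc(Cl)c2)cc1` gives 94%, and compound 3 `O=C(O)CCc1ccc(C#Cc2ccccn2)cc1` gives 98%. Compound 2 and compound 1 differ in a single place, (methyl in place of hydrogen on an aromatic carbon), and this change produced a number 7 percentage points higher from compound 2 to compound 1 (within the scatter). The values of compound 3 and compound 2 lie within the scatter of each other; the difference between their two cores is not broken down here.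

Compound 4 `Cc1cccc(C#Cc2ccc(CCC(=O)O)cc2)n1` has not yet been measured in this assay. It differs from compound 3 by methyl in place of hydrogen on an aromatic carbon. Among the measured compounds shown here, this is the same kind of change as the one from compound 2 to compound 1, though the surroundings differ: in compound 1 the methyl stands ortho to a chloro group, ortho to a large group and two atoms from the ring nitrogen, whereas in compound 4 it stands next to the ring nitrogen and meta to a large group.

For compound 4 a step of a number 2 percentage points higher from compound 3 to compound 4 (within the scatter) is expected, because the earlier change gave a number 7 percentage points higher from compound 2 to compound 1 (within the scatter) and compound 3 already gives 98%. Compound 4 is therefore estimated at 100%, between 86% and 112%.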

Compound 4, largest response reached (reported as efficacy), in percent of the reference or control that the assay uses: 108%
Compound 4: the middle estimate sits 8 percentage points below what was measured, within the range that was stated.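

In this assay, methyl in place of hydrogen on an aromatic carbon gives a number 10 percentage points higher from compound 3 to compound 4 (within the scatter). Set beside the earlier case, the step on the second core agrees with the first: the same change on two cores in this assay, a number 7 percentage points higher (within the scatter) from compound 2 to compound 1 and a number 10 percentage points higher (within the scatter) from compound 3 to compound 4, 3 percentage points apart, within the scatter of two such steps. This shows that the size of the step did not differ measurably between the two cores, even though the methyl stands in different surroundings, but each step lies within the scatter, so it does not show that the methyl changes the maximal response on either core, and two cores cannot speak for the whole series.

The compounds shown leave open whether an ethyl or a methoxy group in the same place, next to the ring nitrogen, would read like the methyl of compound 4. They also leave open whether a methyl on the core of compound 4 would give a similar reading in any other place on that ring.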